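This account rests on a few compounds, and the source may have more. Where it says the series, first, only, none or still open, it means among the compounds named here.

Three acids sharing one core have been measured in an assay on Prostate gland for inhibition of 3-oxo-5-alpha-steroid 4-dehydrogenase 2 (Rattus norvegicus); on this read-out higher numbers stand for weaker inhibition and lower numbers for stronger inhibition. Compound 1 `O=C(O)c1ccc(C=C2CCN(C(=O)C(C3CCCCC3)C3CCCCC3)CC2)cc1` gives 80 nM; compound 3 `O=C(O)c1ccc(C=C2CCN(C(=O)C(c3ccccc3)c3ccccc3)CC2)cc1` gives 370 nM; compound 2 `O=C(O)c1ccc(C=C2CCN(C(=O)CC(c3ccccc3)c3ccccc3)CC2)cc1` gives 880 nM. Compound 1 thus stands at the lowest number of the three, its gaps to compound 3 and to compound 2 both lying beyond the scatter, so within this small set it counts as the strongest inhibitor.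

Compound 4 `O=C(O)Cc1ccc(C=C2CCN(C(=O)C(C3CCCCC3)C3CCCCC3)CC2)c(F)c1` keeps the rest of compound 1 unchanged and alters only the aryl end: 4-(carboxymethyl)-2-fluorophenyl in place of 4-carboxyphenyl on a double-bonded chain carbon bound to a double-bonded ring carbon. Going by the values given here, no measured pair in the set isolates this change, so its size in this assay cannot be read from neighbours; the acid now sits in a carboxymethyl group and a fluorine is added, as the name 4-(carboxymethyl)-2-fluorophenyl states. Without a precedent, the expected step of a 1.9-fold higher number from compound 1 to compound 4 (0.27 log units; within the scatter) is taken as small, toward the weaker side if anything, and not clearly beyond the scatter. Compound 4 is therefore estimated at 150 nM, with a range from 40 nM to 600 nM.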

Compound 4, half-maximal inhibitory concentration: 38 nM
Beside the measured number, compound 4's estimate is 3.9-fold (0.60 log units) above it, outside the stated range (below it).
By their numbers in this assay, from the lowest: compound 4; then compound 1; then compound 3; then compound 2.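

In this assay, going by these compounds alone, the earlier compounds varied only the far end of the molecule, whereas this result shows that the aryl end on a double-bonded chain carbon bound to a double-bonded ring carbon also affects inhibition. Placing 4-(carboxymethyl)-2-fluorophenyl in place of 4-carboxyphenyl gives a 2.1-fold lower number from compound 1 to compound 4 (0.32 log units; beyond the scatter) and the step is modest, so with the rest of compound 1 unchanged, the acid need not stand directly on the aromatic ring for inhibition to be kept. Nothing measured here accounts for the step.

The change combines the carboxymethyl group and the fluorine, and the compounds shown do not divide the step between them. Still open, as far as these compounds go, is how a 4-(carboxymethyl)phenyl group without fluorine, or a longer carboxyethyl chain, would compare at this position.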